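Swapping Chloro for Methyl on a Weak Antiproliferative

The compounds below may be only part of what the source reports. "The series", "measured", "known", "first", "only" and "open" are said of these compounds alone.

Of the compounds shown here, three sharing one core have been measured in a functional assay on A-375 cells (Homo sapiens) for antiproliferative activity, read by CCK-8 assay, with a stated time of 72 h, tested at 8 uM; on this read-out lower numbers stand for a weaker effect and higher numbers for a stronger effect at the one concentration tested. Compound 1 `Nc1ccccc1NC(=O)c1ccc(CSC(=S)N2CCN(c3ccc(Cl)cc3)CC2)cc1` gives 29% and stands lowest of the three, with both other values beyond the scatter above it. Compound 2 `Nc1ccccc1NC(=O)c1ccc(CSC(=S)N2CCCc3ccccc32)cc1` gives 81.5%, and compound 3 `CCN(Cc1ccncc1)C(=S)SCc1ccc(C(=O)Nc2ccccc2N)cc1` gives 86.2%. For the measured compounds named here, the one step between neighbours that differ in a single place, a number 4.7 percentage points higher from compound 2 to compound 3 (within the scatter), concerns the group on the thiocarbonyl carbon, ethyl((pyridin-4-yl)methyl)amino in place of 1,2,3,4-tetrahydroquinolin-1-yl.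

Compound 4 `Cc1ccc(N2CCN(C(=S)SCc3ccc(C(=O)Nc4ccccc4N)cc3)CC2)cc1` differs from compound 1 by methyl in place of chloro on an aromatic carbon, so that 4-chlorophenyl becomes 4-methylphenyl. Going by the values given here, no measured step touches this part of the molecule; the only step known lies on the thiocarbonyl carbon and is itself within the scatter, so it says nothing about methyl in place of chloro on an aromatic carbon. With nothing to suggest movement, the expected step is a number 4 percentage points higher from compound 1 to compound 4 (within the scatter), within the scatter. Compound 4 is therefore estimated at 33%, with a range from 15% to 55%.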

Compound 4, a percentage reported as inhibition, at one concentration (the size of the read-out at that concentration, not a potency): 26.4%
Beside the measured number, compound 4's estimate is 6.6 percentage points above it, and the stated range covers the measured number.
By their numbers in this assay, from the lowest: compounds 4 and 1 (each within the scatter of the next); then compounds 2 and 3 (each within the scatter of the next).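

Methyl in place of chloro on an aromatic carbon, para to a large group, comes with a number 2.6 percentage points lower from compound 1 to compound 4 (within the scatter), so in this assay this exchange of one heavy atom for another produces no change that can be read. The low reading of compound 1 therefore does not depend on the chloro group alone: with methyl at the same place, compound 4 gives 26.4%. Nothing measured here offers a reason for this result.

The compounds shown leave open whether an amine, a carboxylic acid or a methoxy group on this same aromatic carbon would read any differently from chloro and methyl. They also leave open whether the low numbers belong to the substituent at this position or to the whole 4-chlorophenyl or 4-methylphenyl group that carries it.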